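The source may report more compounds than this note shows. Statements on the series, on what has been measured and on what is new or still open speak of the compounds shown alone.

Within the data shown here, in a functional assay on COLO 205 cells (Homo sapiens) for inhibition, read by sulforhodamine B assay (on this read-out lower numbers stand for stronger inhibition of growth and higher numbers for weaker inhibition of growth), compound 3 `Oc1ccc(-c2ccc(-c3ccc(-c4nc5ccccc5[nH]4)cc3)cc2)cc1` gives 100000 nM as its value, level with compound 2 `FC(F)(F)Oc1ccc(-c2ccc(-c3ccc(-c4nc5ccccc5[nH]4)cc3)cc2)cc1` at 100000 nM and together the highest of the three numbers so far. Compound 4 `Clc1cccc(-c2ccc(-c3ccc(-c4nc5ccccc5[nH]4)cc3)cc2)c1` differs from compound 3 in one place, with 3-chlorophenyl in place of 4-hydroxyphenyl on an aromatic carbon. Among the measured compounds shown here, the only measured step (no change at the digits printed from compound 2 to compound 3 (within the scatter)) alters a group on the oxygen and offers little guidance here. For the measured compounds named here, compound 1 `Cc1ccc2[nH]c(-c3ccc(-c4ccc(-c5cccc(Cl)c5)cc4)cc3)nc2c1` carries 3-chlorophenyl on its own core and stands at 2780 nM as the only number for that group, so a lower number in this assay is expected, of uncertain size. The expected step is a 13-fold lower number from compound 3 to compound 4 (1.10 log units; beyond the scatter) (an estimate). Compound 4 is estimated at 8000 nM (expected range 1500 nM to 100000 nM).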

Compound 4, concentration for 50% growth inhibition: 100000 nM
The estimate for compound 4 lay 13-fold (1.10 log units) below the measured number, within the range that was stated.
By their numbers in this assay, from the lowest: compound 1; then compounds 2, 3 and 4 (each within the scatter of the next).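

In this assay the change to 3-chlorophenyl gives no change at the digits printed from compound 3 to compound 4 (within the scatter) and so, on this unmethylated core, does not separate itself from 4-hydroxyphenyl. Among these compounds, the methyl on the core of compound 1 now stands out: hydrogen in its place gives a 36-fold higher number from compound 1 to compound 4 (1.56 log units; beyond the scatter) and this is the only step so far beyond the scatter. No measured evidence explains this difference.

Going by these compounds, whether an ethyl group, a methoxy group or an amine on that carbon would match methyl remains open. So does whether methyl would have the same effect alongside the end groups of compound 2 and compound 3.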